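A few compounds are considered here, and "the series" means these few. Any claim that something is new, unique, unknown or untested is made for them only; others in the source may bear on it.

Values in a functional assay on COLO 205 cells (Homo sapiens) for cytotoxicity (a lower number here means a stronger inhibitor, a higher number a weaker inhibitor), so far

- compound 1 `Cc1ccc(S(=O)(=O)N/C(=N\O)Nc2ccc(Cl)cc2)cc1` gives 58 ug/mL
- compound 2 `O=S(=O)(N/C(=N\O)Nc1ccc(Cl)cc1)c1ccccc1` gives 53 ug/mL
- compound 3 `O=S(=O)(N/C(=N\O)Nc1ccc(Cl)cc1)c1cccc2snnc12` gives 87 ug/mL

Compound 2 is not separated from compound 1 or compound 3, since both lie within the scatter of it. The next structure is compound 4 `N#Cc1c(Cl)cccc1Oc1ccc(S(=O)(=O)N/C(=N\O)Nc2ccc(Cl)cc2)cc1`, which has 3-chloro-2-cyanophenoxy in place of hydrogen on an aromatic carbon, para to a large group (3-chloro-2-cyanophenoxy in place of hydrogen on an aromatic carbon). Among the measured compounds shown here, one measured step bears on this carbon: a 1.1-fold lower number from compound 1 to compound 2 (0.04 log units; within the scatter) for hydrogen in place of methyl. That step is small and within the scatter, but methyl is a far smaller group than the one entering here, so it sets only a weak guide. For the measured compounds named here, no measured compound carries a comparable group, and the data give no firm direction. A small move to a lower number is assumed, with no step beyond the scatter firmly expected. The expected change is a 1.4-fold lower number from compound 2 to compound 4 (0.14 log units; within the scatter) in this estimate. For compound 4 the estimated value is 38 ug/mL, with an expected range of 14 ug/mL to 90 ug/mL.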

Compound 4, half-maximal inhibitory concentration: 178 ug/mL
Compound 4: middle estimate off by 4.7-fold (0.67 log units), on the low side, outside the stated range (above it).
By their numbers in this assay, from the lowest: compounds 2, 1 and 3 (each within the scatter of the next); then compound 4.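

Among the compounds shown here, this carbon, para to a large group, gives the first step that lies beyond the scatter in this assay: 3-chloro-2-cyanophenoxy in place of hydrogen gives a 3.4-fold higher number from compound 2 to compound 4 (0.53 log units; beyond the scatter), and in place of methyl it gives a 3.1-fold higher number from compound 1 to compound 4 (0.49 log units; beyond the scatter). Hydrogen and methyl on this carbon cannot be told apart, whereas 3-chloro-2-cyanophenoxy, with its 10 heavy atoms, shifts the series modestly toward weaker inhibition. Nothing on hand accounts for this shift.

The compounds shown leave open whether the shift belongs to the phenoxy ring itself or to its chlorine and nitrile, which an unsubstituted phenoxy would separate. Also open, as far as these compounds go, is how this carbon responds to small groups such as methoxy, an amine or a carboxylic acid, and whether any group here gives a lower number than hydrogen.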